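Fluoro for nitro on the weakest of three anilines

This account rests on a few compounds, and the source may have more. Where it says the series, first, only, none or still open, it means among the compounds named here.

Of the compounds shown here, three have been tested in an assay on HEK293 cells for displacement of a labelled ligand from Neuronal acetylcholine receptor; alpha3/beta4 (Homo sapiens); a higher number here means a weaker inhibitor, a lower number a stronger inhibitor. Compound 1 `COc1ccc(Nc2cncc(N3CC4CC(C3)N4)c2)cc1` gives 2.2 nM, and compound 3 `FC(F)(F)c1ccc(Nc2cncc(N3CC4CC(C3)N4)c2)cc1` gives 1.02 nM; these two share one core and differ only in the group on the aniline ring, a trifluoromethyl in place of methoxy on an aromatic carbon, which gave a 2.2-fold lower number from compound 1 to compound 3 (0.33 log units; beyond the scatter). Compound 2 `O=[N+]([O-])c1ccc(Nc2ccc(N3CC4CC(C3)N4)cn2)cc1` is built on a different core and gives 25 nM, the highest number of the three, well above compound 1 and further still from compound 3.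

Compound 4 `Fc1ccc(Nc2ccc(N3CC4CC(C3)N4)cn2)cc1` keeps the core of compound 2 and changes only the aniline substituent: fluoro in place of nitro on an aromatic carbon. Going by the values given here, no measured pair shows this exact exchange on either core. Among the compounds with values here, the only step that bears on it at all is the one from compound 1 to compound 3, a modest one, and it shows that two quite different groups on an aromatic carbon of that ring are both tolerated. On that basis one expects a small step in this assay, more likely toward a lower number than a higher one, with the estimate for compound 4 at 14 nM within 4 nM to 50 nM, a change of a 1.8-fold lower number from compound 2 to compound 4 (0.25 log units; within the scatter) that is expected rather than known.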

Compound 4, inhibition constant: 13 nM
Beside the measured number, compound 4's estimate is 1.1-fold (0.03 log units) above it, and the stated range covers the measured number.
By their numbers in this assay, from the lowest: compound 3; then compound 1; then compounds 4 and 2 (each within the scatter of the next).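

On the core of compound 2, the aromatic carbon para to a large group now has a direct reading in this assay: a 1.9-fold lower number from compound 2 to compound 4 (0.28 log units; within the scatter), a step that stays inside the usual scatter. The earlier step from methoxy to trifluoromethyl belonged to the other core and said nothing of this core, whereas this pair shows that nitro, with its three heavy atoms and two hydrogen-bond acceptors, can give way to fluoro, with one heavy atom and no counted acceptor, without a step beyond the scatter. Nothing shown here accounts for this result, and no measurement speaks to what either group does at this position.

The compounds shown hold no pair that carries one aniline substituent on both cores, so the share of the core in the gap between their numbers stays open, and it remains unclear whether fluoro or nitro would behave the same way on the core of compound 1. Also open, from the compounds shown here alone, is whether a group of another kind on this aromatic carbon, such as an amine or a carboxylic acid, would stay equally close to compound 2 in this assay.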